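Chloro in place of bromo: from compound 2 to compound 4

The source may hold more compounds than are shown below. What is called first, only, known or untested is meant among the compounds shown, and "the series" means these compounds.

The series shares one core, carried by compound 2 `CCOC(=O)C1=Cc2ccccc2OC1(OCc1cc(-c2ccc(Br)cc2)no1)C(F)(F)F`, compound 1 `CCOC(=O)C1=Cc2ccccc2OC1(OCc1cn(CC(=O)Nc2ccccc2Br)nn1)C(F)(F)F` and compound 3 `CCOC(=O)C1=Cc2ccccc2OC1(OCc1cn(-c2cccc(C(F)(F)F)c2)nn1)C(F)(F)F`. In a functional assay on MCF7 cells (Homo sapiens) for inhibition, read by MTT assay, with a stated time of 24 h (on this read-out higher numbers stand for weaker inhibition and lower numbers for stronger inhibition), compound 2 reaches only a limit, > 150000 nM. In this assay compound 1 likewise gives only a limit, > 150000 nM. Compound 3 in this assay also gives only a limit, > 150000 nM. Within the data shown here, the single step between measured compounds, a step that the two limits leave unreadable from compound 1 to compound 3, cannot be read, since both of its ends sit at the limit of > 150000 nM in this assay, at which 3 of the 3 values shown sit. Among the measured compounds shown here, no measured step therefore bears on the change to compound 4 `CCOC(=O)C1=Cc2ccccc2OC1(OCc1cc(-c2ccc(Cl)cc2)no1)C(F)(F)F`, which differs from compound 2 as follows: chloro in place of bromo on an aromatic carbon. With nothing readable to go on, the expectation is that compound 4 stays at the limit as well, a step that the limit leaves unreadable from compound 2 to compound 4 that would not rise beyond the scatter. Compound 4 is accordingly estimated at 200000 nM, within a range from 60000 nM to 1000000 nM, most likely reported as a limit again.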

Compound 4, half-maximal inhibitory concentration: 18200 nM
The estimate for compound 4 lay 11-fold (1.04 log units) above the measured number, and the stated range ends above it.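

In this assay, the change from 4-bromophenyl to 4-chlorophenyl gives an at least 8.2-fold lower number from compound 2 to compound 4 (0.91 log units; beyond the scatter), so one halogen exchange on an aromatic carbon, para to a large group, is enough to produce a measurable number in this series. Compound 4 is the only compound shown that gives a number rather than a limit: the limit of > 150000 nM in this assay, at which 3 of the 4 values shown sit. The value of compound 2 is a limit, so this step gives a lower bound on the size of the change and not its exact size.

On these data alone, whether fluoro, methyl or an amine at this same place would give a lower or a higher number remains open. Also open, as far as these compounds go, is whether the gain from chloro holds when the ethyl ester of the shared core is replaced by a carboxylic acid.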